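Dimethylamino in Place of Ethylamino: Expectation for Compound 4

The source may report more compounds than this note shows. Statements on the series, on what has been measured and on what is new or still open speak of the compounds shown alone.

Three compounds have been measured in a functional assay on MCF7 cells (Homo sapiens) for antiproliferative activity, read by MTT assay, with a stated time of 48 h; on this read-out lower numbers stand for stronger inhibition and higher numbers for weaker inhibition:
compound 1, `C=C(c1ccc(OC)cc1NC(=O)CNCC)c1ccc(OC)c2c1C=CC(C)(C)O2`, gives 2920 nM;
compound 2, `C=C(c1ccc2c(c1)C=CC(C)(C)O2)c1ccc(OC)cc1NC(=O)CNCC`, gives 3370 nM;
compound 3, `C=C(c1ccc(OC)cc1NC(=O)CN(C)C)c1ccc(OC)c2c1C=CC(C)(C)O2`, gives 2580 nM.

The step from compound 1 to compound 3 is dimethylamino in place of ethylamino on a saturated chain carbon bound to a carbonyl carbon and changes the number by a 1.1-fold lower number from compound 1 to compound 3 (0.05 log units; within the scatter). Compound 2 differs from compound 1 in its core; the difference between the two cores is not broken down here. Compound 2 and compound 1 give numbers within the usual scatter of each other.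

Compound 4, `C=C(c1ccc2c(c1)C=CC(C)(C)O2)c1ccc(OC)cc1NC(=O)CN(C)C`, is not yet measured. It differs from compound 2 by dimethylamino in place of ethylamino on a saturated chain carbon bound to a carbonyl carbon, the same change already seen from compound 1 to compound 3. The estimated step from compound 2 to compound 4 is a 1.1-fold lower number from compound 2 to compound 4 (0.05 log units; within the scatter), which is expected to sit beside the earlier one because of a 1.1-fold lower number from compound 1 to compound 3 (0.05 log units; within the scatter). Compound 4 is therefore expected to give about 3000 nM in this assay, between 1500 nM and 6000 nM.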

Compound 4, half-maximal inhibitory concentration: 940 nM
Estimate against measurement, compound 4: 3.2-fold (0.50 log units) above, outside the stated range (below it).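

In this assay, dimethylamino in place of ethylamino on a saturated chain carbon bound to a carbonyl carbon gives a 3.6-fold lower number from compound 2 to compound 4 (0.55 log units; beyond the scatter). Among the compounds shown here, with only two cores compared, the result does not show which part of the cores governs the size of this step, nor why the size differs. It does show that, in this series, the change cannot be carried from one core to the other at a fixed size: the same change on two cores in this assay, a 1.1-fold lower number (0.05 log units; within the scatter) from compound 1 to compound 3 and a 3.6-fold lower number (0.55 log units; beyond the scatter) from compound 2 to compound 4, 3.2-fold (0.50 log units) apart, beyond the scatter of two such steps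

The compounds shown leave open whether other groups on the same chain, such as diethylamino or an unsubstituted amino group, would also differ from core to core. They also leave open whether the larger step on the core of compound 2 would persist with a longer chain.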